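Aryl swap at the shared core: paw edema working notes

A few compounds are considered here, and "the series" means these few. Any claim that something is new, unique, unknown or untested is made for them only; others in the source may bear on it.

Measured in a functional assay on the whole organism (strain Wistar) for inhibition, with Rattus norvegicus as the target, read by paw edema, with stated times of 30 min and 3 h, at a dose of 200 mg/kg by the oral route; on this read-out higher numbers stand for more inhibition at the one dose given (going by the name of the read-out) and lower numbers for less inhibition:
compound 1 `O=C(O)c1cccc(-n2c(-c3ccccc3)cc3c2CCCC3)c1`: 20%
compound 2 `O=C(O)c1cc(-n2c(-c3ccccc3)cc3c2CCCC3)cc(Br)c1O`: 0%
compound 3 `COc1cccc(-c2cc3c(n2-c2ccc(O)c(C(=O)O)c2)CCCC3)c1`: 20%

Compound 3 stands level with compound 1 at the digits shown, the pair together the highest of the three numbers, and the gap between them lies within the scatter. Compound 2 is the furthest from compound 3, lower by an amount beyond the scatter. Going by the values given here, no two measured compounds differ in only one place, so no single change has a measured step attached to it.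

Compound 4 `N#Cc1ccc(-c2cc3c(n2-c2ccc(O)c(C(=O)O)c2)CCCC3)cc1` is not yet measured. It carries the change (4-cyanophenyl in place of 3-methoxyphenyl on an aromatic carbon). Nothing in the measured set isolates an aryl swap of this kind, so the step is expected to be small and of no clear direction, not beyond the scatter. For compound 4 the expected value in this assay is 15%, within 0% to 35%. The estimated step is a number 5 percentage points lower from compound 3 to compound 4 (within the scatter).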

Compound 4, a percentage reported as inhibition, in the whole organism at one dose (the size of the read-out at that dose, not a potency): 0%
Beside the measured number, compound 4's estimate is 15 percentage points above it; the range from low to high includes it.
By their numbers in this assay, from the lowest: compounds 2 and 4 (each within the scatter of the next); then compounds 1 and 3 (each within the scatter of the next).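

In this assay, going by these compounds alone, the change to 4-cyanophenyl in place of 3-methoxyphenyl gives a number 20 percentage points lower from compound 3 to compound 4 (beyond the scatter) and is the only single change with a measured step. For this pair, the aromatic carbon next to the ring nitrogen is not indifferent to which aryl group it carries. Nothing measured here gives a reason for the step.

The two aryl groups differ in both the substituent and where it sits, so the step cannot be assigned to either. A 4-methoxyphenyl or 3-cyanophenyl group on this carbon would separate the two.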